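The source may hold more compounds than are shown below. What is called first, only, known or untested is meant among the compounds shown, and "the series" means these compounds.

Measured compounds in the series:

compound 1 `CS(=O)(=O)c1ccc(C(=O)N2CCC(C(=O)N(Cc3ccccc3)c3ccccc3)CC2)cc1[N+](=O)[O-]`
compound 2 `CN(Cc1ccccc1)C(=O)C1CCN(C(=O)c2ccc(S(C)(=O)=O)c([N+](=O)[O-])c2)CC1`

In an assay on isolated protein for inhibition of vitamin D3 receptor (Homo sapiens), read by fluorescence polarization (a higher number here means a weaker inhibitor, a lower number a stronger inhibitor), compound 1 reaches only the limit of the assay, > 60000 nM. In this assay compound 2 likewise reaches only the limit, > 60000 nM. For the measured compounds named here, both readings sit at the same limit (the limit of > 60000 nM in this assay, at which 2 of the 2 values shown sit), so compound 2 stands at a limit and not at a number, and the one measured step, a step that the two limits leave unreadable from compound 1 to compound 2, is of unreadable size.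

Compound 3 `CS(=O)(=O)c1ccc(C(=O)N2CCC(C(=O)N(Cc3ccccc3)Cc3ccccc3)CC2)cc1[N+](=O)[O-]` differs from compound 2 by phenyl in place of hydrogen on a saturated chain carbon bound to an amide-type nitrogen. Going by the values given here, the measured step from compound 1 to compound 2 concerns the substituent on the same amide-type nitrogen, methyl in place of phenyl, and is unreadable; no other step is available. Among the compounds with values here, the structural change to compound 3 thus has no measured step that gives it a size or a direction. With both neighbours at the limit, the expected step of a number no higher from compound 2 to compound 3 (the limit leaves the size open) is none beyond the scatter, and the likeliest outcome is again a limit rather than a number. Compound 3 is estimated at 60000 nM, in the range 15000 nM to 200000 nM.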

Compound 3, half-maximal inhibitory concentration: > 60000 nM
Compound 3: a limit, no number; the forecaster's own chance of this, stated with the estimate: 80%; the middle value sits exactly at the limit.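

In this assay compound 3 gives > 60000 nM, which is a limit and not a number. No new step can be read among compound 1, compound 2 and compound 3, as all three stand at the same limit: the limit of > 60000 nM in this assay, at which 3 of the 3 values shown sit.

As far as these compounds go, whether any substituent on the amide-type nitrogen of the shared core gives a number rather than a limit in this assay stays open.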